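A few compounds are considered here, and "the series" means these few. Any claim that something is new, unique, unknown or untested is made for them only; others in the source may bear on it.

Three compounds share one core and differ only in the aromatic group attached to a carbon with a double bond to nitrogen. Compound 1 `CN(C)CCn1cnnc1-c1cc(Oc2ccc(NC(=O)N/N=C/c3cccc(Br)c3)cc2F)ccn1` carries a 3-bromophenyl group, and in a functional assay on NCI-H460 cells (Homo sapiens) for cytotoxicity, read by MTT assay, with a stated time of 72 h (on this read-out lower numbers stand for stronger inhibition and higher numbers for weaker inhibition), compound 1 gives 520 nM. Compound 2 `CN(C)CCn1cnnc1-c1cc(Oc2ccc(NC(=O)N/N=C/c3cccc(O)c3)cc2F)ccn1` carries a 3-hydroxyphenyl group; in this assay compound 2 gives 780 nM, the second highest number of the three, nearest to compound 1 and furthest from compound 3. Compound 3 `CN(C)CCn1cnnc1-c1cc(Oc2ccc(NC(=O)N/N=C/c3ccc(O)c(F)c3)cc2F)ccn1` gives 2620 nM in this assay. The step of a 1.5-fold higher number from compound 1 to compound 2 (0.18 log units; within the scatter) was small, whereas a 3.4-fold higher number from compound 2 to compound 3 (0.53 log units; beyond the scatter) and a 5.0-fold higher number from compound 1 to compound 3 (0.70 log units; beyond the scatter) were modest weakenings. Compound 4 `CN(C)CCn1cnnc1-c1cc(Oc2ccc(NC(=O)N/N=C/c3cc(Br)c(O)c(Br)c3)cc2F)ccn1` is not yet measured; it differs from compound 2 in that (3,5-dibromo-4-hydroxyphenyl in place of 3-hydroxyphenyl on a carbon with a double bond to nitrogen). Because compound 3 with its 4-hydroxy group shows 2620 nM, a modest weakening is expected, about a 2.1-fold higher number from compound 2 to compound 4 (0.31 log units; beyond the scatter). Compound 4 is therefore estimated at 1600 nM, within a range from 500 nM to 5000 nM.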

Compound 4, half-maximal inhibitory concentration: 3760 nM
Beside the measured number, compound 4's estimate is 2.4-fold (0.37 log units) below it, within the range that was stated.
By their numbers in this assay, from the lowest: compounds 1 and 2 (each within the scatter of the next); then compounds 3 and 4 (each within the scatter of the next).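

Carrying bromine on this aromatic group does not by itself keep the number low in this assay, as two bromines and a hydroxy give a 7.2-fold higher number from compound 1 to compound 4 (0.86 log units; beyond the scatter). Adding those groups also costs ground against the simple hydroxy compound, with a 4.8-fold higher number from compound 2 to compound 4 (0.68 log units; beyond the scatter). The two 4-hydroxy groups cannot be told apart, with a 1.4-fold higher number from compound 3 to compound 4 (0.16 log units; within the scatter), which holds for fluorine and for two bromines alike.

Nothing available here explains these differences. Going by these compounds, it also stays open whether the plain 4-hydroxyphenyl group, or an amine or a carboxylic acid on this ring, would follow the same trend.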